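The compounds below may be only part of what the source reports. "The series", "measured", "known", "first", "only" and "open" are said of these compounds alone.

Measured compounds in an assay on K177 cells for activation of Neuronal acetylcholine receptor; alpha4/beta2 (Homo sapiens); on this read-out lower numbers stand for an effect already at smaller amounts and higher numbers for an effect only at larger amounts of compound:

- compound 1 `Cc1ncccc1OC[C@@H]1CCCN1C`, 4800 nM
- compound 2 `Cc1ccncc1OC[C@@H]1CCCN1C`, 2100 nM
- compound 3 `CN1CCC[C@H]1COc1cncc(Br)c1`, 5950 nM

Compound 3 gives the highest of the three numbers in this assay. Its nearest neighbour is compound 1, whose value of 4800 nM lies within the scatter of the value of compound 3, so the two cannot be told apart. Among the compounds with values here, compound 2, with 2100 nM, stands beyond the scatter from compound 3 and is the only pair in the set separated by more than the usual variation.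

The next compound to be considered is compound 4 `Cc1cncc(OC[C@@H]2CCCN2C)c1`. It differs from compound 3 by methyl in place of bromo on an aromatic carbon. Within the data shown here, both compound 1 and compound 2 already carry a methyl on their six-membered aromatic ring with one nitrogen, at positions other than the one occupied in compound 4, and both give numbers at or below that of compound 3. Among the measured compounds shown here, no step between measured compounds of this kind is available, so the size of the change cannot be read from the present data.

The expectation for compound 4 is a modest move toward a smaller number, a 1.5-fold lower number from compound 3 to compound 4 (0.17 log units; within the scatter), on the basis that compound 1 gives 4800 nM and compound 2 gives 2100 nM with a methyl on the same ring. The estimated value for compound 4 in this assay is 4000 nM, with a range from 1500 nM to 10000 nM.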

Compound 4, half-maximal effective concentration: 2300 nM
Compound 4: middle estimate off by 1.7-fold (0.24 log units), on the high side, within the range that was stated.
By their numbers in this assay, from the lowest: compounds 2 and 4 (each within the scatter of the next); then compounds 1 and 3 (each within the scatter of the next).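

Within the data shown here, the change reads in this assay as a 2.6-fold lower number from compound 3 to compound 4 (0.41 log units; beyond the scatter) and is the first step that can be read between two measured compounds, and it lies beyond the scatter. At this aromatic carbon, two atoms from the ring nitrogen and meta to a group of 8 heavy atoms, one heavy atom replaces one heavy atom, with no ring, hydrogen-bond donor, hydrogen-bond acceptor or net charge entering or leaving, yet the number still moves beyond the scatter. Nothing at hand gives a measured reason for this step, so it stands as an observation on this one pair.

The compounds shown leave open how fluoro, methoxy, a nitrile or an amine at this same carbon would compare with bromo and methyl, and whether a longer chain such as ethyl would extend or reverse the step. They also leave open whether the same exchange of bromo for methyl would give a step of similar size at another aromatic carbon of the shared core.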